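A few compounds are considered here, and "the series" means these few. Any claim that something is new, unique, unknown or untested is made for them only; others in the source may bear on it.

Measured compounds in a functional assay on MDA-MB-231 cells (Homo sapiens) for cytotoxicity, read by MTT assay, with a stated time of 72 h; on this read-out higher numbers stand for weaker inhibition and lower numbers for stronger inhibition:
Compound 1 `FC(F)(F)c1ccc(CSc2nc(Nc3ccccc3C(F)(F)F)c3ccccc3n2)cc1` gives only a limit of the assay, > 50000 nM.
Compound 2 `CCOc1ccccc1Nc1nc(SCc2ccc(C(F)(F)F)cc2)nc2ccccc12` likewise gives only a limit, > 50000 nM.
Compound 3 `FC(F)(F)c1ccc(CSc2nc(Nc3cccc(C(F)(F)F)c3)c3ccccc3n2)cc1` gives 11100 nM.

Compound 3 thus stands as the only one of the three with a number in this assay; the other two sit at the limit of > 50000 nM in this assay, at which 2 of the 3 values shown sit. Compound 4 `Fc1ccc(Nc2nc(SCc3ccc(C(F)(F)F)cc3)nc3ccccc23)cc1` is not yet measured and differs from compound 3 by 4-fluorophenyl in place of 3-(trifluoromethyl)phenyl on a nitrogen on an aromatic ring. Among the compounds with values here, two measured steps bear on this change, since both alter the same aryl group on the same nitrogen: an at least 4.5-fold lower number from compound 1 to compound 3 (0.65 log units; beyond the scatter) and an at least 4.5-fold lower number from compound 2 to compound 3 (0.65 log units; beyond the scatter). Within the data shown here, in each, the 3-(trifluoromethyl)phenyl end carried the lower number, and no measured pair tests a 4-fluorophenyl. A somewhat higher number is therefore expected for compound 4, a step of a 2.3-fold higher number from compound 3 to compound 4 (0.35 log units; beyond the scatter). Compound 4 is estimated at 25000 nM, within 6000 nM to 60000 nM.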

Compound 4, half-maximal inhibitory concentration: 15000 nM
Compound 4: middle estimate off by 1.7-fold (0.22 log units), on the high side; the measured number falls inside the stated range.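

A second aryl group on this nitrogen now gives a number in this assay, and 4-fluorophenyl does not separate from 3-(trifluoromethyl)phenyl, with a 1.4-fold higher number from compound 3 to compound 4 (0.13 log units; within the scatter). A number at this position therefore does not depend on a trifluoromethyl group on this phenyl, and 4-fluorophenyl also parts from the other two groups, with an at least 3.3-fold lower number from compound 2 to compound 4 (0.52 log units; beyond the scatter) and an at least 3.3-fold lower number from compound 1 to compound 4 (0.52 log units; beyond the scatter). Compound 1 and compound 2 remain limits of the assay, not numbers: the limit of > 50000 nM in this assay, at which 2 of the 4 values shown sit.

The compounds shown leave open what these two compounds would give as numbers. They also leave open what an amine or a carboxylic acid on this phenyl would give.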